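A few compounds are considered here, and "the series" means these few. Any claim that something is new, unique, unknown or untested is made for them only; others in the source may bear on it.

Among the measured compounds shown here, compound 2 `CCCCS(=O)(=O)c1sc2nc(-c3cccs3)cc(-c3ccccc3)c2c1N` gives 25 nM in an assay for inhibition of 15-hydroxyprostaglandin dehydrogenase [NAD(+)] (Homo sapiens), read by fluorescence, with a stated time of 15 min, in the presence of a further agent that is not named here (on this read-out lower numbers stand for stronger inhibition and higher numbers for weaker inhibition), the highest of the two numbers measured so far; its only neighbour, compound 1 `CCC[S+]([O-])c1sc2nc(-c3cccs3)cc(-c3ccccc3)c2c1N`, gives 2.1 nM. Compound 3 `CCCCCC[S+]([O-])c1sc2nc(-c3cccs3)cc(-c3ccccc3)c2c1N` is not yet measured. The change from compound 2 to compound 3 is a group of 8 heavy atoms (6 carbon, 1 oxygen, 1 sulfur; no ring) in place of a group of 7 heavy atoms (4 carbon, 2 oxygen, 1 sulfur; no ring), on an aromatic carbon. For the measured compounds named here, the one step that bears on it, a 12-fold higher number from compound 1 to compound 2 (1.08 log units; beyond the scatter), runs the other way across a related exchange on the aromatic carbon, so a move back downward is expected, beyond the scatter though not necessarily all the way. Compound 3 is expected at 5 nM, within 1.5 nM to 15 nM, an estimated step of a 5.0-fold lower number from compound 2 to compound 3 (0.70 log units; beyond the scatter).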

Compound 3, half-maximal inhibitory concentration: 18 nM
Estimate against measurement, compound 3: 3.6-fold (0.56 log units) below; the whole stated range lies below it.
By their numbers in this assay, from the lowest: compound 1; then compounds 3 and 2 (each within the scatter of the next).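

In this assay, the chain alone moves the number at this position: with the sulfur group's single oxygen kept, the longer chain gives an 8.6-fold higher number from compound 1 to compound 3 (0.93 log units; beyond the scatter). The exchange of butylsulfonyl for the hexyl-bearing group gives a 1.4-fold lower number from compound 2 to compound 3 (0.14 log units; within the scatter), so the earlier step from compound 1 to compound 2 cannot be read as an effect of the second oxygen alone, since that step also lengthens the chain. Nothing at hand gives a cause for either step.

Open, on these data alone, is how a propylsulfonyl group compares with compound 1 at equal chain length. Also open, as far as these compounds go, is whether a butyl chain on the single-oxygen sulfur group, or a chain ending in an amine, stays near compound 1 or near compound 3.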